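This account rests on a few compounds, and the source may have more. Where it says the series, first, only, none or still open, it means among the compounds named here.

In a functional assay on CCRF-CEM cells (Homo sapiens) for inhibition (on this read-out lower numbers stand for stronger inhibition and higher numbers for weaker inhibition), compound 1 (`Cn1cc(C#N)c2ccc(Nc3ncc(-c4cccc(NC(=O)c5ccccc5)c4)o3)cc21`) gives 3500 nM, compound 2 (`Cn1cc(C#N)c2ccc(Nc3ncc(-c4cccc(CNC(=O)c5ccccc5)c4)o3)cc21`) gives 5300 nM and compound 3 (`Cn1cc(C#N)c2ccc(Nc3ncc(-c4cccc(CNC(=O)c5ccc6ccccc6c5)c4)o3)cc21`) gives 4400 nM. These three values lie within the scatter of one another, so compound 3 does not stand apart from either of the other two. Compound 4 (`Cn1cc(C#N)c2ccc(Nc3ncc(-c4cccc(CNC(=O)OCCC#N)c4)o3)cc21`) has 2-cyanoethoxy in place of naphthalen-2-yl on a carbonyl carbon. Within the data shown here, two measured steps bear on this change. The closer one, naphthalen-2-yl in place of phenyl on the same carbonyl carbon, gave a 1.2-fold lower number from compound 2 to compound 3 (0.08 log units; within the scatter). Benzamidomethyl in place of benzamido on an aromatic carbon gave a 1.5-fold higher number from compound 1 to compound 2 (0.18 log units; within the scatter). Neither step tests a carbonyl substituent without an aromatic ring, so the measured compounds offer only limited guidance here. No change beyond the scatter is therefore expected in this assay. The estimated step is a 1.1-fold higher number from compound 3 to compound 4 (0.06 log units; within the scatter). Compound 4 is expected to give about 5000 nM, with an estimated range of 2000 nM to 12000 nM.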

Compound 4, half-maximal inhibitory concentration: > 10000 nM
Compound 4 gave a limit, no number; the forecaster's own chance of this, stated with the estimate: 10%; at least 2.0-fold (0.30 log units) between middle value and limit.
By their numbers in this assay, from the lowest: compounds 1, 3 and 2 (each within the scatter of the next). At a limit, above all of these: compound 4.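

In this assay compound 4 gives a limit and not a number: the limit of > 10000 nM in this assay, at which 1 of the 4 values shown sits. On this carbonyl carbon, whose other neighbour is an amide-type nitrogen, swapping one aromatic group for another had stayed within the scatter, whereas 2-cyanoethoxy gives an at least 2.2-fold higher number from compound 3 to compound 4 (0.35 log units; beyond the scatter), and the comparison with the benzamido compound gives an at least 2.8-fold higher number from compound 1 to compound 4 (0.45 log units; beyond the scatter). The comparison with the phenyl compound gives an at least 1.8-fold higher number from compound 2 to compound 4 (0.27 log units; that floor lies within the scatter), so on its own this floor does not separate those two compounds.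

On these data alone, it remains open whether the higher number goes with the loss of the aromatic rings, with the oxygen now on the carbonyl carbon or with the nitrile, and the limit gives no true size for the step. A plain ethoxy or a benzyloxy group on the same carbonyl carbon would help separate these possibilities.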